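Deacetylation of the benzyl hydroxamate ester in compound 1

A few compounds are considered here, and "the series" means these few. Any claim that something is new, unique, unknown or untested is made for them only; others in the source may bear on it.

Measured compounds:
compound 1 `CC(=O)Oc1ccc(CONC(=O)c2ccc(CS(=O)(=O)Nc3ccc4cc(C)c(=O)n(C)c4c3)cc2)cc1` — 1%
compound 2 `Cc1cc2cc(NS(=O)(=O)c3cc(C(=O)NO)ccc3Cl)ccc2n(C)c1=O` — 8%
compound 3 `COc1ccc(C(=O)NOCc2ccc(OC(C)=O)cc2)cc1S(=O)(=O)Nc1ccc2c(c1)cc(C)c(=O)n2C` — 3%

All three numbers come from a functional assay on THP-1 cells (Homo sapiens) for antiproliferative activity, tested at 20 uM; on this read-out lower numbers stand for a weaker effect and higher numbers for a stronger effect at the one concentration tested. Compound 1, at 1%, stands at the bottom of the three, but compound 3 lies within the scatter of it and so does compound 2, the one furthest from it, so the three compounds cannot be told apart on this read-out. Among the compounds with values here, nothing in the set so far produces a clear effect, and no step between two measured compounds is available to show what any single structural change does here.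

Compound 4 `Cc1cc2ccc(NS(=O)(=O)Cc3ccc(C(=O)NOCc4ccc(O)cc4)cc3)cc2n(C)c1=O` is the next member. It differs from compound 1 in one place: hydrogen in place of acetyl on an oxygen on an aromatic ring. Across the three measured compounds every variation of the hydroxamate part has left the read-out near the floor, compound 2 included, which offers no hint that removing the acetyl should move the number out of that region. The step expected from compound 1 to compound 4 is therefore none beyond the scatter, a number 3 percentage points higher from compound 1 to compound 4 (within the scatter), in no settled direction. Compound 4 is estimated at 4%, within a range from 0% to 15%, because compound 1 gives 1% and the change is small.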

Compound 4, a percentage reported as inhibition, at one concentration (the size of the read-out at that concentration, not a potency): 1%
For compound 4 the middle estimate is 3 percentage points above the measured one; the measured number falls inside the stated range.
By their numbers in this assay, from the lowest: compounds 1, 4, 3 and 2 (each within the scatter of the next).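

The series now has its first step that can be read at one place: in this assay the exchange of acetoxy for hydroxy gives no change at the digits printed from compound 1 to compound 4 (within the scatter). The acetyl on this oxygen on an aromatic ring can therefore be removed without any visible consequence on this read-out, with compound 1 at 1% and compound 4 at 1%. No accompanying measurement bears on this result, so the step can be stated but not interpreted.

The step shows only that this one exchange leaves the number unmoved at the single concentration tested, on a scale where nothing shown gives a clear effect, so it cannot tell whether this place matters at all; an amine or a carboxylic acid in place of the hydroxy on the ring would be a wider test of that. Going by these compounds, it also remains open whether the same exchange of acetoxy for hydroxy reads the same way on compound 3, where the rest of the molecule differs.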